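Removing the methoxy of compound 1: what to expect

This account rests on a few compounds, and the source may have more. Where it says the series, first, only, none or still open, it means among the compounds named here.

Among the compounds with values here, compound 1, `COc1ccc(/C(=C\c2c[nH]c3ccc(OCc4ccccc4)cc23)C(=O)O)cc1`, is the only compound with a number in a functional assay on M14 cells (Homo sapiens) for cytotoxicity, read by MTT assay, with a stated time of 72 h (a higher number here means a weaker inhibitor, a lower number a stronger inhibitor), where compound 1 gives 58400 nM. Compound 2, `COc1ccc(/C(=C\c2cn(C(C)=O)c3ccc(OCc4ccccc4)cc23)C(=O)O)cc1`, carries an acetyl in place of hydrogen on an aromatic nitrogen. In this assay compound 2 reaches only a limit, > 100000 nM. The step of an at least 1.7-fold higher number from compound 1 to compound 2 (0.23 log units; that floor lies within the scatter) therefore rests on (the limit of > 100000 nM in this assay, at which 1 of the 2 values shown sits). Compound 3, `O=C(O)/C(=C/c1c[nH]c2ccc(OCc3ccccc3)cc12)c1ccccc1`, differs from compound 1 at another site: hydrogen in place of methoxy on an aromatic carbon, so that 4-methoxyphenyl becomes phenyl. Within the data shown here, no measured step touches this change; the single measured step concerns the aromatic nitrogen and is itself bounded by a limit. With nothing to point one way or the other, the step of a 1.0-fold higher number from compound 1 to compound 3 (0.01 log units; within the scatter) is expected to be none beyond the scatter. In this assay compound 3 is estimated at 60000 nM, within 25000 nM to 150000 nM.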

Compound 3, half-maximal inhibitory concentration: 95200 nM
Beside the measured number, compound 3's estimate is 1.6-fold (0.20 log units) below it, within the range that was stated.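

In this assay, within the data shown here, replacing the methoxy with hydrogen gives a 1.6-fold higher number from compound 1 to compound 3 (0.21 log units; within the scatter), the first reading at this place on the ring, as the only earlier step concerned the aromatic nitrogen. Going from 4-methoxyphenyl to phenyl therefore does not separate the two compounds, and the methoxy is not shown to matter for this read-out. Neither compound gives a strong number, and the only other compound shown reaches just a limit, so this comparison sits at the weak end of the values: the limit of > 100000 nM in this assay, at which 1 of the 3 values shown sits.

On these data alone, whether another group at this place, such as a hydroxyl, a fluorine or an amine, would move the number beyond the scatter stays open. Also open, as far as these compounds go, is how the loss of the methoxy reads when an acetyl sits on the aromatic nitrogen.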